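The source may report more compounds than this note shows. Statements on the series, on what has been measured and on what is new or still open speak of the compounds shown alone.

Working notes on the series. Compound 1 `O=C1/C(=C/c2ccccc2F)CN(S(=O)(=O)c2ccc(O[N+](=O)[O-])cc2)C/C1=C\c1ccccc1F` and compound 2 `O=C1/C(=C/c2cccc(F)c2)CN(S(=O)(=O)c2ccc(O[N+](=O)[O-])cc2)C/C1=C\c1cccc(F)c1` share a core that differs only in where fluorine sits on the two outer rings. In a functional assay on HepG2 cells (Homo sapiens) for cytotoxicity, read by MTT assay, with a stated time of 24 h (on this read-out higher numbers stand for weaker inhibition and lower numbers for stronger inhibition), compound 1 gives 16500 nM, and in this assay compound 2 gives 8100 nM, the lower of the two numbers, with the gap to compound 1 beyond the scatter. Compound 3 `CC(=O)Nc1ccc(S(=O)(=O)N2C/C(=C\c3cccc(F)c3)C(=O)/C(=C/c3cccc(F)c3)C2)cc1` carries the change (acetamido in place of nitrooxy on an aromatic carbon), acetamido in place of nitrooxy on an aromatic carbon. Within the data shown here, no step of this kind has been measured, so only a modest step toward a higher number is expected, a 1.5-fold higher number from compound 2 to compound 3 (0.17 log units; within the scatter). Compound 3 is estimated at 12000 nM in this assay, with a range from 5000 nM to 30000 nM.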

Compound 3, half-maximal inhibitory concentration: 11100 nM
For compound 3 the middle estimate is 1.1-fold (0.03 log units) above the measured one; low and high end bracket the measured number.
By their numbers in this assay, from the lowest: compounds 2, 3 and 1 (each within the scatter of the next, the first and the last beyond it).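

Read in this assay acetamido in place of nitrooxy on an aromatic carbon, para to a large group, gives a 1.4-fold higher number from compound 2 to compound 3 (0.14 log units; within the scatter) and so stays within the scatter. Nitrooxy is therefore not required at this position for a number of this size, at least with the fluorine placement of compound 2. No data are at hand that explain this result.

As far as these compounds go, whether an amine or a carboxylic acid at this place would read the same remains open. So does whether acetamido behaves alike with the fluorine placement of compound 1.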